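One group swapped where the measurements reach a limit

The source may hold more compounds than are shown below. What is called first, only, known or untested is meant among the compounds shown, and "the series" means these compounds.

Measured in an ADME assay on HepG2 cells (Homo sapiens) for cytotoxicity; a higher number here means that more compound is needed for the effect, a lower number that less compound is needed:
Compound 1 `Cc1ccc(S(=O)(=O)N[C@@H](CC(=O)NC(C)(C)C)C(=O)NCCNC(=O)NCc2ccccc2)cc1`: > 11000 nM
Compound 2 `Cc1ccc(S(=O)(=O)N[C@@H](CC(=O)NC(C)(C)C)C(=O)NCCNC(=O)c2cc(C)ccn2)cc1`: > 11000 nM

Compound 2 stands at > 11000 nM in this assay, which is a limit and not a number. Compound 1 is no firmer, and the whole record so far is the limit of > 11000 nM in this assay, at which 2 of the 2 values shown sit.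

Compound 3 `Cc1ccc(S(=O)(=O)N[C@@H](CC(=O)NC(C)(C)C)C(=O)NCCNC(=O)c2ccc(F)c(F)c2)cc1` keeps the shared core of compound 2 and alters one group: 3,4-difluorophenyl in place of 4-methylpyridin-2-yl on a carbonyl carbon. In plain words, 3,4-difluorophenyl takes the place of 4-methylpyridin-2-yl on a carbonyl carbon.

Among the measured compounds shown here, only one measured step bears on this place, and that is a step that the two limits leave unreadable from compound 1 to compound 2. It offers no size to carry over. Still, neither of the two groups tried on this carbonyl carbon gave a number in this assay, so a third group is expected to leave the result much the same, with no shift beyond the scatter. The estimate is a step that the limit leaves unreadable from compound 2 to compound 3, an expected step that is small and without a firm direction. Compound 3 is expected at 12000 nM, with an estimated range from 6000 nM to 30000 nM.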

Compound 3, half-maximal effective concentration: > 11000 nM
Compound 3: no number, only a limit; the forecaster's own chance of this, stated with the estimate: 85%; the middle value lies beyond the limit too.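

In this assay compound 3 gives > 11000 nM, which is a limit and not a number. Compound 1 and compound 2 also rest on limits, so no step among these three compounds can be read. The compounds shown leave open how much of each is needed for the effect, and whether changing the group on this carbonyl carbon alters that amount at all.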